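The source may report more compounds than this note shows. Statements on the series, on what has been measured and on what is new or still open speak of the compounds shown alone.

Compound 1 `OC[C@H]1O[C@@H](n2cnc3c(NCc4ccccc4F)ncnc32)[C@H](O)[C@@H]1O`: 3200 nM
Compound 2 `COc1ccccc1CNc1ncnc2c1ncn2[C@@H]1O[C@H](CO)[C@@H](O)[C@H]1O`: 2300 nM

Both compounds were tested in a functional assay on HL-60 cells (Homo sapiens) for antiproliferative activity, with a stated time of 72 h; a lower number here means a stronger inhibitor, a higher number a weaker inhibitor. Going by the values given here, compound 2 cannot be told apart from compound 1 on these numbers, as the only measured comparison is a 1.4-fold lower number from compound 1 to compound 2 (0.14 log units; within the scatter).

Compound 3 `OC[C@H]1O[C@@H](n2cnc3c(NCc4ccccc4OC(F)(F)F)ncnc32)[C@H](O)[C@@H]1O` keeps the shared core and alters one group of compound 2: trifluoromethyl in place of methyl on an oxygen on an aromatic ring. In words, this is trifluoromethyl in place of methyl on an oxygen on an aromatic ring, or methoxy to trifluoromethoxy.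

Among the compounds with values here, no measured step makes this exact exchange. Within the data shown here, the closest evidence is the single step that changed the same aromatic substituent, methoxy in place of fluoro on an aromatic carbon, and that step was a 1.4-fold lower number from compound 1 to compound 2 (0.14 log units; within the scatter). Among the measured compounds shown here, with only this one small step to go on, no clear shift in this assay is expected in either direction, although a single step offers limited guidance. The estimated step is a 1.1-fold higher number from compound 2 to compound 3 (0.04 log units; within the scatter), which is expected to stay within the scatter. Compound 3 is expected to give 2500 nM, with an estimated range of 1000 nM to 6000 nM.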

Compound 3, half-maximal inhibitory concentration: > 166000 nM
Compound 3 gave a limit, no number; the forecaster's own chance of this, stated with the estimate: 8%; middle value at least 66-fold (1.82 log units) from the limit.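

In this assay compound 3 gives > 166000 nM, which is a limit of the assay and not a number. Putting trifluoromethyl in place of the methyl on this oxygen is a large change, an at least 72-fold higher number from compound 2 to compound 3 (1.85 log units; beyond the scatter), and trifluoromethoxy in place of fluoro on the aromatic carbon is just as clearly beyond the scatter, an at least 51-fold higher number from compound 1 to compound 3 (1.71 log units; beyond the scatter). The earlier exchange of fluoro for methoxy stayed within the scatter, a 1.4-fold lower number from compound 1 to compound 2 (0.14 log units; within the scatter), so the apparent indifference of this place to its substituent does not extend to trifluoromethoxy, while the full size of both new steps stays unknown, as they are bounded from one side only: the limit of > 166000 nM in this assay, at which 1 of the 3 values shown sits.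

The compounds shown do not tell whether this sharp rise belongs specifically to the trifluoromethyl group or would also follow from another group on the same oxygen, such as an ethyl. Nor do they show whether a hydroxyl or a trifluoromethyl attached directly to the aromatic carbon, with no oxygen in between, would read like methoxy or like trifluoromethoxy.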